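A few compounds are considered here, and "the series" means these few. Any claim that something is new, unique, unknown or untested is made for them only; others in the source may bear on it.

Compound 1 `COc1ccc(C(OCc2ccccc2)c2cccc3ccccc23)c(OC)c1OC`: > 20000 nM (a limit)
Compound 2 `COc1ccc(/C(=N/OCC(=O)O)c2cccc3ccccc23)c(OC)c1OC`: > 20000 nM (a limit)

In a functional assay on THP-1 cells (Homo sapiens) for inhibition, read by sulforhodamine B assay, with a stated time of 48 h (a higher number here means a weaker inhibitor, a lower number a stronger inhibitor), compound 1 gives only a limit, > 20000 nM, and not a number. Compound 2 likewise gives only a limit, > 20000 nM. Among the compounds with values here, neither compound therefore has a measured potency, and no step between close relatives is available to size a structural change.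

Compound 3 `COc1ccc(C(c2ccc(O)cc2)c2cccc3ccccc23)c(OC)c1OC` has not yet been measured. It differs from compound 1 by a single change, 4-hydroxyphenyl in place of benzyloxy on a saturated chain carbon bound to two aromatic carbons.

In this assay, a modest move towards stronger inhibition is expected, held with little confidence, and another result that is only a limit would be no surprise. The estimated step is an at least 1.4-fold lower number from compound 1 to compound 3 (0.15 log units; that floor lies within the scatter). For compound 3 the estimated value is 14000 nM, with an expected range of 5000 nM to 30000 nM.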

Compound 3, half-maximal inhibitory concentration: 9450 nM
Beside the measured number, compound 3's estimate is 1.5-fold (0.17 log units) above it; the measured number falls inside the stated range.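

Compound 3 is the first of the compounds shown to give a number rather than a limit in this assay, so a saturated chain carbon bound to two aromatic carbons is now a place where a change can be sized. Putting 4-hydroxyphenyl in place of benzyloxy there gives an at least 2.1-fold lower number from compound 1 to compound 3 (0.32 log units; beyond the scatter), and the change keeps one six-membered aromatic ring while bringing in 1 hydrogen-bond donor where benzyloxy has 0. The true size of this step stays unknown because its starting point is only a limit: the limit of > 20000 nM in this assay, at which 2 of the 3 values shown sit.

On these data alone, it remains open whether the hydroxyl of the 4-hydroxyphenyl group carries the step, or whether a plain phenyl, a 4-methoxyphenyl or an amine at this place would do the same. Also open, as far as these compounds go, is how far the value of compound 3 depends on the rest of the shared core.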